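Chloro in place of ethoxy on the outer aromatic ring

A few compounds are considered here, and "the series" means these few. Any claim that something is new, unique, unknown or untested is made for them only; others in the source may bear on it.

Three compounds share one core and differ only in the group on a double-bonded ring carbon. Compound 3 `CCOc1ccc(NC2=C(C(=O)c3ccccc3)C(c3ccc(Br)cc3)N(CCCn3ccnc3)C2=O)cc1` carries a (4-ethoxyphenyl)amino group there; in a functional assay on NCI-H1299 cells (Homo sapiens) for antiproliferative activity, read by MTT assay, with a stated time of 72 h (on this read-out lower numbers stand for stronger inhibition and higher numbers for weaker inhibition), compound 3 gives 20000 nM. Compound 1 `CCCCCOC1=C(C(=O)c2ccccc2)C(c2ccc(Br)cc2)N(CCCn2ccnc2)C1=O` carries pentyloxy and gives 10300 nM in this assay, while compound 2 `O=C(C1=C(OC2CCCCC2)C(=O)N(CCCn2ccnc2)C1c1ccc(Br)cc1)c1ccccc1` carries cyclohexyloxy and gives 19900 nM. The number for compound 3 is the highest of the three, yet the steps of a 1.9-fold higher number from compound 1 to compound 3 (0.29 log units; within the scatter) and a 1.0-fold higher number from compound 2 to compound 3 (0.00 log units; within the scatter) both lie within the scatter, as does a 1.9-fold higher number from compound 1 to compound 2 (0.29 log units; within the scatter), so the three compounds cannot be told apart on these numbers.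

Compound 4 `O=C(C1=C(Nc2ccc(Cl)cc2)C(=O)N(CCCn2ccnc2)C1c1ccc(Br)cc1)c1ccccc1` has not been measured. It differs from compound 3 by chloro in place of ethoxy on an aromatic carbon. For the measured compounds named here, none of the measured steps touches this aromatic ring; each exchanged the whole group on the double-bonded ring carbon, and each stayed within the scatter. Going by the values given here, with no step that bears on the change, the expectation for compound 4 is no shift beyond the scatter, no change at the digits printed from compound 3 to compound 4 (within the scatter). Compound 4 is therefore estimated at 20000 nM, with a range from 8000 nM to 50000 nM.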

Compound 4, half-maximal inhibitory concentration: 25000 nM
Estimate against measurement, compound 4: 1.3-fold (0.10 log units) below; low and high end bracket the measured number.
By their numbers in this assay, from the lowest: compounds 1, 2, 3 and 4 (each within the scatter of the next, the first and the last beyond it).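

In this assay, for the compounds shown here, this is the first change made on the outer aromatic ring itself, and exchanging ethoxy for chloro there gives no readable difference (a 1.3-fold higher number from compound 3 to compound 4 (0.10 log units; within the scatter)). Going by these compounds alone, the (4-chlorophenyl)amino group also cannot be told apart from cyclohexyloxy on the double-bonded ring carbon (a 1.3-fold higher number from compound 2 to compound 4 (0.10 log units; within the scatter)), but against pentyloxy it gives the first step in this set that lies beyond the scatter, though only a modest one (a 2.4-fold higher number from compound 1 to compound 4 (0.39 log units; beyond the scatter)). Nothing available explains these numbers.

Ethoxy and chloro are only two groups at this place on the ring, so an amine or a carboxylic acid there might behave differently. The compounds shown also leave open whether a longer chain on the oxygen would differ from pentyloxy.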